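The compounds below may be only part of what the source reports. "The series", "measured", "known", "first", "only" and "open" are said of these compounds alone.

Compound 1 `CC(=O)N[C@@H]1CCN(c2cc(C)nn3c(-c4ccc(C(F)(F)F)cc4)c(C)nc23)C1`: > 95%
Compound 2 `CC(=O)N[C@@H]1CCN(c2cc(C)nn3c(-c4ccc(C#N)cc4)c(C)nc23)C1`: > 95%

In an ADME assay on microsomes from liver (Homo sapiens) for metabolic stability, read by LC-MS, with NADPH named in the record, with a stated time of 60 min, tested at 1 uM, in the absence of a further agent (on this read-out lower numbers stand for a less stable compound and higher numbers for a more stable compound), compound 2 gives > 95%, which is a limit and not a number. Compound 1 gives > 95%, also a limit. The two compounds share (the limit of > 95% in this assay, at which 2 of the 2 values shown sit). For the measured compounds named here, the only measured step is a step that the two limits leave unreadable from compound 1 to compound 2, so it offers no size to carry forward. Compound 3 `COc1cc(-c2c(C)nc3c(N4CC[C@@H](NC(C)=O)C4)cc(C)nn23)ccc1F` differs from compound 2 at one place: 4-fluoro-3-methoxyphenyl in place of 4-cyanophenyl on an aromatic carbon. Neither measured compound carries this new group, so the expectation is loose. With compound 2 at > 95%, a high reading is still expected. The expected change is a number at least 10 percentage points lower from compound 2 to compound 3 (that floor lies within the scatter), a modest fall. For compound 3 the estimate is 85%, with an expected range of 60% to 100%.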

Compound 3, percent of the compound remaining: > 95%
Compound 3 gave a limit, no number; the forecaster's own chance of this, stated with the estimate: 35%; middle value at least 10 percentage points from the limit.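

Compound 1, compound 2 and compound 3 each give only a limit in this assay, so no step among them can be read: the limit of > 95% in this assay, at which 3 of the 3 values shown sit.

Going by these compounds, whether the 4-(trifluoromethyl)phenyl, 4-cyanophenyl and 4-fluoro-3-methoxyphenyl groups differ at all in this assay stays open.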